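A few compounds are considered here, and "the series" means these few. Any claim that something is new, unique, unknown or untested is made for them only; others in the source may bear on it.

Measured so far:
compound 1, `Cn1c(-c2ccc(NC(=O)CN3CCN(c4ccccc4)CC3)cc2)nc(-c2ccccc2)c1-c1ccccc1`, 59.6%
compound 2, `Cn1c(-c2ccc(NC(=O)CN3CCN(Cc4ccccc4)CC3)cc2)nc(-c2ccccc2)c1-c1ccccc1`, 28.3%

Within the data shown here, in a functional assay on MCF7 cells (Homo sapiens) for cytotoxicity, read by MTT assay, with a stated time of 24 h, tested at 16 ug/mL (on this read-out higher numbers stand for a stronger effect at the one concentration tested and lower numbers for a weaker effect), compound 2 stands lowest of the two numbers; the only step measured runs a number 31.3 percentage points lower from compound 1 to compound 2 (beyond the scatter). Compound 3, `Cn1c(-c2ccc(NC(=O)CN3CCN(Cc4ccc(Cl)cc4)CC3)cc2)nc(-c2ccccc2)c1-c1ccccc1`, differs from compound 2 by chloro in place of hydrogen on an aromatic carbon. Among the measured compounds shown here, no measured step touches a chloro on this ring; the one step known concerns benzyl in place of phenyl and does not bear on this change. With nothing to go on, the account expects no step beyond the scatter, a change of a number 1.7 percentage points higher from compound 2 to compound 3 (within the scatter). Compound 3 is therefore estimated at 30%, with a range from 15% to 50%.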

Compound 3, a percentage reported as activity, at one concentration (the size of the read-out at that concentration, not a potency): 46.2%
Compound 3: the middle estimate sits 16.2 percentage points below what was measured; measured number inside the range.
By their numbers in this assay, from the lowest: compound 2; then compound 3; then compound 1.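

In this assay, chloro in place of hydrogen on the benzyl ring gives a number 17.9 percentage points higher from compound 2 to compound 3 (beyond the scatter) and so shows that this ring is not indifferent to a substituent at this place. Set against phenyl, 4-chlorobenzyl still gives a number 13.4 percentage points lower from compound 1 to compound 3 (beyond the scatter) and so the chloro closes only part of the gap opened by benzyl. No evidence on hand accounts for this gain. From the compounds shown here alone, whether a fluoro, a methoxy or a nitro group at this place would do the same stays open, as does the effect of a chloro on the phenyl of compound 1.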